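The compounds below may be only part of what the source reports. "The series", "measured", "known", "first", "only" and "open" are said of these compounds alone.

In an assay for inhibition of zeta-carotene desaturase, chloroplastic/chromoplastic (Capsicum annuum), using a Dixon plot, with a stated time of 8 h (on this read-out higher numbers stand for weaker inhibition and lower numbers for stronger inhibition), compound 2 `CCC(COc1cccc(OC)c1)OC(=O)NCc1ccccc1` gives only a limit, > 100000 nM. Compound 1 `CCC(COc1ccccc1)OC(=O)NCc1ccccc1` likewise gives only a limit in this assay, > 100000 nM. Going by the values given here, the single measured step, a step that the two limits leave unreadable from compound 1 to compound 2, stays unreadable because both values sit at the limit of > 100000 nM in this assay, at which 2 of the 2 values shown sit. Compound 3 `CCOC(=O)c1cccc(OCC(CC)OC(=O)NCc2ccccc2)c1` differs from compound 2 by ethoxycarbonyl in place of methoxy on an aromatic carbon. No readable step bears on this change, so neither its direction nor its size can be drawn from the two compounds in hand. Compound 3 is therefore estimated at 150000 nM, with a range from 30000 nM to 800000 nM. This expected value corresponds to a step that the limit leaves unreadable from compound 2 to compound 3.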

Compound 3, half-maximal inhibitory concentration: > 100000 nM
Compound 3 was reported as a limit; the forecaster's own chance of this, stated with the estimate: 80%; the middle value does not contradict the limit.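

No step can be read among compound 1, compound 2 and compound 3, because all three give only the same limit: the limit of > 100000 nM in this assay, at which 3 of the 3 values shown sit. As far as these compounds go, whether methoxy or ethoxycarbonyl on the aromatic carbon changes inhibition at all remains open.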